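Thiazolyl replacing fluoro on the aryl of compound 1

The source may hold more compounds than are shown below. What is called first, only, known or untested is meant among the compounds shown, and "the series" means these compounds.

Measured compounds in an assay on RBL-1 cells for inhibition of Polyunsaturated fatty acid 5-lipoxygenase (Rattus norvegicus); a higher number here means a weaker inhibitor, a lower number a stronger inhibitor:
compound 1 `O=C1NCCN(c2cccc(F)c2)N1`, 19000 nM
compound 2 `CC1CN(c2cccc(F)c2)NC(=O)N1`, 6300 nM
compound 3 `O=C1NCCN(c2cccnc2)N1`, 32000 nM

Compound 1 stands second highest of the three numbers. Its nearest neighbour is compound 3, whose value sits within the scatter of compound 1, so no order between the two is claimed. Among the measured compounds shown here, the only step beyond the scatter runs from compound 1 to compound 2: a 3.0-fold lower number from compound 1 to compound 2 (0.48 log units; beyond the scatter), a change on the saturated ring of the shared core.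

Compound 4 `O=C1NCCN(c2cccc(-c3nccs3)c2)N1` differs from compound 1 on the aryl ring: 1,3-thiazol-2-yl in place of fluoro on an aromatic carbon. For the measured compounds named here, no measured step touches a substituent on this ring; the pair compound 1 and compound 3 exchanges the whole ring for another and its two values fall within the scatter of each other. Going by the values given here, the one step that is beyond the scatter, from compound 1 to compound 2, concerns a different part of the molecule and gives no direct guide to the size or direction here.

Among the compounds with values here, with no comparable step in hand, the expectation for compound 4 is a number close to that of compound 1, the estimated step being a 1.6-fold lower number from compound 1 to compound 4 (0.20 log units; within the scatter), with a wide range on either side. The estimate for compound 4 in this assay is 12000 nM, expected to lie between 3000 nM and 45000 nM.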

Compound 4, half-maximal inhibitory concentration: 35000 nM
For compound 4 the middle estimate is 2.9-fold (0.46 log units) below the measured one; the range from low to high includes it.
By their numbers in this assay, from the lowest: compound 2; then compounds 1, 3 and 4 (each within the scatter of the next).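

Working notes on the aryl position: in this assay, exchanging fluoro for 1,3-thiazol-2-yl on an aromatic carbon gives a 1.8-fold higher number from compound 1 to compound 4 (0.27 log units; within the scatter) and is the first step in the series that changes only a substituent on this ring. The position therefore carries a five-membered aromatic ring with 2 hetero atoms in place of a single fluorine with no step beyond the scatter, so the two groups cannot be told apart in this read-out. Among the compounds shown here, the only step beyond the scatter remains a 3.0-fold lower number from compound 1 to compound 2 (0.48 log units; beyond the scatter), made on a saturated ring carbon and not on the aryl ring, and nothing available bears on why the aryl exchange reads as it does.

As far as these compounds go, it remains open whether an amine, a carboxylic acid or a longer alkyl chain on the same aromatic carbon would give a step beyond the scatter, since a single exchange at this position cannot define its tolerance. Also open, from the compounds shown here alone, is whether the methyl on the saturated ring carbon would give a similar step when 1,3-thiazol-2-yl occupies the aryl position.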